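From Methyl to Isobutyl on the Shared Core

The source may hold more compounds than are shown below. What is called first, only, known or untested is meant among the compounds shown, and "the series" means these compounds.

Among the compounds with values here, in a functional assay on HeLa cells (Homo sapiens) for cytotoxicity, read by MTT assay (a lower number here means a stronger inhibitor, a higher number a weaker inhibitor), compound 1 (`C[C@H](NC(=S)Nc1cc(C(F)(F)F)cc(C(F)(F)F)c1)c1nc2ccccc2[nH]1`) gives 133000 nM and holds the only number available. Compound 2 (`CC(C)[C@@H](NC(=S)Nc1ccccc1)c1nc2ccccc2[nH]1`) is recorded as "not active" (no number reported) with no figure reported, so compound 1 cannot be ranked against it. Compound 3 (`CC(C)C[C@H](NC(=S)Nc1cc(C(F)(F)F)cc(C(F)(F)F)c1)c1nc2ccccc2[nH]1`) keeps the core of compound 1 and changes one place: isopropyl in place of hydrogen on a saturated chain carbon, two bonds along the chain from an amide-type nitrogen and an aromatic carbon with isopropyl in place of hydrogen on a saturated chain carbon, two bonds along the chain from an amide-type nitrogen and an aromatic carbon. Cut one bond further out, this reads methyl to isobutyl. Within the data shown here, no measured step speaks to this change, so the expectation rests only on compound 1 at 133000 nM as its starting point. In this assay the expected change is small and toward stronger inhibition, estimated as a 1.5-fold lower number from compound 1 to compound 3 (0.17 log units; within the scatter) in this account. Compound 3 is estimated at 90000 nM with a range from 30000 nM to 250000 nM as its expected span.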

Compound 3, half-maximal inhibitory concentration: 18100 nM
Compound 3: middle estimate off by 5.0-fold (0.70 log units), on the high side; the whole stated range lies above it.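

In this assay the saturated chain carbon, two bonds along the chain from an amide-type nitrogen and an aromatic carbon, now has its first measured step: isopropyl in place of hydrogen, which reads methyl to isobutyl when cut one bond further out, gives a 7.3-fold lower number from compound 1 to compound 3 (0.87 log units; beyond the scatter) on the shared core. Compound 1 alone could not show whether the number moves with the group at this place, and this single step shows that it does for this change, beyond the usual scatter. Nothing measured here accounts for the step.

Steps involving compound 2 cannot be read, as it has no number. Open, going by these compounds, is whether a longer chain or a cyclohexyl ring at this place would lower the number further, and whether an amine there would keep the step.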